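A few compounds are considered here, and "the series" means these few. Any claim that something is new, unique, unknown or untested is made for them only; others in the source may bear on it.

Measured compounds in an assay on isolated protein for binding affinity to adenosine receptor A1 (Bos taurus); a higher number here means a weaker inhibitor, a lower number a stronger inhibitor:
- compound 1 `COc1ccc(C(=O)Nc2nc(-c3ccccc3)nc3c2nnn3Cc2ccccc2F)cc1`, which gives 21900000 nM
- compound 2 `FC(F)(F)c1ccccc1Cn1nnc2c(NC3CCCC3)nc(-c3ccccc3)nc21`, which gives 600000 nM
- compound 3 `CNc1nc(-c2ccccc2)nc2c1nnn2Cc1ccccc1`, which gives 353000000 nM

Compound 1 holds the second highest of the three numbers. Its gap to compound 3, the nearest, is beyond the scatter, as is its larger gap to compound 2, which shows the lowest number of the set. Going by the values given here, no pair among the measured compounds differs in a single place, so no single-point step is available as a guide.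

Compound 4 `CC(O)CNc1nc(-c2ccccc2)nc2c1nnn2Cc1ccccc1F` is not yet measured. Its difference from compound 1 is 2-hydroxypropyl in place of (4-methoxyphenyl)carbonyl on a nitrogen on an aromatic ring. Both neighbouring measured compounds carry other substituents at this nitrogen and on the benzyl group at once, so the expected effect can only be read roughly: compound 3 with its small group on this nitrogen shows the weakest binding, compound 2 the strongest. For compound 4 a step of a 1.4-fold higher number from compound 1 to compound 4 (0.14 log units; within the scatter) is expected, likely within or only just beyond the scatter, in the direction of weaker binding. The estimate for compound 4 is 30000000 nM, with a range from 3000000 nM to 300000000 nM.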

Compound 4, inhibition constant: 4800000 nM
Compound 4: middle estimate off by 6.3-fold (0.80 log units), on the high side; low and high end bracket the measured number.
By their numbers in this assay, from the lowest: compound 2; then compound 4; then compound 1; then compound 3.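

In this assay, the substituent on this nitrogen on an aromatic ring moves the number on its own, with the rest of the molecule held constant: a 4.6-fold lower number from compound 1 to compound 4 (0.66 log units; beyond the scatter). The earlier compounds shown here differed in more than one place and could not isolate this position, whereas here the step is modest but beyond the scatter. The change removes the carbonyl and the six-membered aromatic ring and adds a hydroxyl-bearing chain in one move, and no supporting data point to a cause of the step.

Which part of the change carries the step remains open, as the comparison cannot separate loss of the carbonyl from loss of the aromatic ring or gain of the hydroxyl. A plain propyl chain, an acetyl group or a benzyl group on this nitrogen would help to separate these parts.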